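Methyl on the Chain Carbon of Compound 1

A few compounds are considered here, and "the series" means these few. Any claim that something is new, unique, unknown or untested is made for them only; others in the source may bear on it.

Compound 1 `O=C(O)CNc1nc(-c2ccccc2)nc2ccccc12`: 0% in a functional assay on the whole organism (strain Wistar) for inhibition, with Rattus norvegicus as the target, read by paw edema, at a dose of 100 mg/kg by the oral route; a lower number here means less inhibition, a higher number more inhibition at the dose given (going by the name of the read-out)
Compound 2 `O=C(O)CNc1nc(-c2ccccc2)nc2ccc(I)cc12`: 0% in this assay

Compound 1 stands level with compound 2 at the digits shown, and the step of no change at the digits printed from compound 1 to compound 2 (within the scatter) was no change within the scatter. Compound 3 `C[C@H](Nc1nc(-c2ccccc2)nc2ccccc12)C(=O)O` carries the change (methyl in place of hydrogen on a saturated chain carbon bound to a carbonyl carbon and a nitrogen on an aromatic ring). Among the measured compounds shown here, the only measured step touches an aromatic carbon, not the saturated chain carbon, so it bears on this change only as a sign that the shared core gave no inhibition so far. For compound 3 no movement beyond the scatter is expected in this assay, the estimated step being no change at the digits printed from compound 1 to compound 3 (within the scatter). Compound 3 is therefore estimated at 0%, in the range -5% to 15%.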

Compound 3, a percentage reported as inhibition, in the whole organism at one dose (the size of the read-out at that dose, not a potency): 9.3%
Beside the measured number, compound 3's estimate is 9.3 percentage points below it; measured number inside the range.
By their numbers in this assay, from the lowest: compounds 1, 2 and 3 (each within the scatter of the next).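

Methyl in place of hydrogen on the saturated chain carbon is the first change tested at this position, and in this assay it gives a number 9.3 percentage points higher from compound 1 to compound 3 (within the scatter). The position therefore accepts this methyl, yet the reading does not stand clear of compound 1. Nothing measured here bears on this result.

From the compounds shown here alone, whether a longer chain on this carbon, or an ester or amide in place of the carboxylic acid, would move the reading beyond the scatter stays open. So does whether methyl would read the same alongside the iodo of compound 2.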